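Trading the amino link for a direct aryl amide

The source may report more compounds than this note shows. Statements on the series, on what has been measured and on what is new or still open speak of the compounds shown alone.

compound 1 `COc1cc(-c2nn(-c3cccc(NC(=O)Nc4cc(C(F)(F)F)cc(C(F)(F)F)c4)c3)cc2-c2ccncc2)ccc1Cl` gives 1870 nM in a functional assay on HCC 2998 cells (Homo sapiens) for inhibition, read by sulforhodamine B assay, with a stated time of 48 h; on this read-out lower numbers stand for stronger inhibition of growth and higher numbers for weaker inhibition of growth
compound 2 `COc1cc(-c2nn(-c3cccc(NC(=O)Nc4ccc(Cl)c(Cl)c4)c3)cc2-c2ccncc2)ccc1Cl` gives 6200 nM in this assay
compound 3 `O=C(Nc1cccc(-n2cc(-c3ccncc3)c(-c3ccc(Cl)c(O)c3)n2)c1)Nc1ccc(Cl)c(Cl)c1` gives 13900 nM in this assay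

Compound 2 holds the second highest of the three numbers. Its nearest neighbour is compound 3, reached by a 2.2-fold higher number from compound 2 to compound 3 (0.35 log units; beyond the scatter), which replaces methyl with hydrogen on an oxygen of an aromatic ring. Compound 1 stands furthest away with its lower number, 1870 nM, while compound 2 gives 6200 nM.

Compound 4 `COc1cc(-c2nn(-c3cccc(NC(=O)c4ccc(Cl)c(C(F)(F)F)c4)c3)cc2-c2ccncc2)ccc1Cl` differs from compound 2 by 4-chloro-3-(trifluoromethyl)phenyl in place of (3,4-dichlorophenyl)amino on a carbonyl carbon. Among the compounds with values here, no measured step tests this kind of change: a 2.2-fold higher number from compound 2 to compound 3 (0.35 log units; beyond the scatter) touches a different place, and the pair of compound 1 and compound 2 compares two rings that both keep the amino link to the carbonyl carbon. As far as these compounds go, the loss of that hydrogen-bond donor is untested here, so no direction can be read from the data, and the expected step of a 1.6-fold lower number from compound 2 to compound 4 (0.19 log units; within the scatter) is set near zero with a wide range. Compound 4 is therefore expected to give about 4000 nM in this assay, between 1000 nM and 16000 nM.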

Compound 4, concentration for total growth inhibition: > 32500 nM
Compound 4 gave a limit, no number (the forecaster's own chance of this, stated with the estimate: 5%); middle value at least 8.1-fold (0.90 log units) away from the limit.
By their numbers in this assay, from the lowest: compound 1; then compound 2; then compound 3. At a limit, above all of these: compound 4.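

Until now, every compound kept the amino link to the carbonyl carbon, so nothing showed what happens when that link is lost. In this assay, within the data shown here, putting 4-chloro-3-(trifluoromethyl)phenyl in place of (3,4-dichlorophenyl)amino gives an at least 5.2-fold higher number from compound 2 to compound 4 (0.71 log units; beyond the scatter), so at this position the direct aryl amide inhibits growth more weakly than the urea-type link of the earlier compounds. The value of compound 4 is a limit and not a number: the limit of > 32500 nM in this assay, at which 1 of the 4 values shown sits.

This single change removes the amino link and also alters the ring, so the compounds shown cannot say which of the two accounts for the loss. A 4-chloro-3-(trifluoromethyl)phenylamino group on the same carbonyl carbon would separate the two, and a methylene in place of the amino link remains an open question.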